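The source may hold more compounds than are shown below. What is called first, only, known or untested is meant among the compounds shown, and "the series" means these compounds.

Measured so far in a functional assay on A549 cells (Homo sapiens) for cytotoxicity, read by MTT assay, with a stated time of 48 h; a lower number here means a stronger inhibitor, a higher number a weaker inhibitor:
compound 1 `N#Cc1ccc(Cn2c(/C=C3\SC(=S)N(CC(=O)O)C3=O)nc3ccccc32)cc1`: 26600 nM
compound 2 `O=C(O)CN1C(=O)/C(=C/c2nc3ccccc3n2Cc2ccc([N+](=O)[O-])cc2)SC1=S`: 11400 nM
compound 3 `O=C(O)CN1C(=O)/C(=C/c2nc3ccccc3n2Cc2ccccc2)SC1=S`: 8760 nM

Compound 1 stands highest of the three numbers in this assay. Its nearest neighbour is compound 2, with a 2.3-fold lower number from compound 1 to compound 2 (0.37 log units; beyond the scatter); its furthest is compound 3, with a 3.0-fold lower number from compound 1 to compound 3 (0.48 log units; beyond the scatter). Between compound 2 and compound 3 there is a 1.3-fold lower number from compound 2 to compound 3 (0.11 log units; within the scatter).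

Compound 4 `O=C(O)CN1C(=O)/C(=C/c2nc3ccccc3n2Cc2ccc(Cl)cc2)SC1=S` has not yet been measured. Its change from compound 1 is chloro in place of cyano on an aromatic carbon. Both measured steps that remove the cyano from compound 1 lowered the number by modest amounts beyond the scatter, so a modest lowering is expected here too, of size a 2.2-fold lower number from compound 1 to compound 4 (0.35 log units; beyond the scatter). For compound 4 the estimate is 12000 nM, expected to lie between 6000 nM and 24000 nM.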

Compound 4, half-maximal inhibitory concentration: 17500 nM
For compound 4 the middle estimate is 1.5-fold (0.16 log units) below the measured one; measured number inside the range.
By their numbers in this assay, from the lowest: compounds 3, 2, 4 and 1 (each within the scatter of the next, the first and the last beyond it).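

Chloro in place of cyano gives a 1.5-fold lower number from compound 1 to compound 4 (0.18 log units; within the scatter) and so stays within the scatter, unlike the two earlier steps away from cyano; leaving cyano at this place is therefore not enough for a step beyond the scatter in this assay. Chloro in place of hydrogen, a 2.0-fold higher number from compound 3 to compound 4 (0.30 log units; within the scatter), and chloro in place of nitro, a 1.5-fold higher number from compound 2 to compound 4 (0.19 log units; within the scatter), are also within the scatter, so compound 4 separates from none of the other three. No data on the cause of these steps are at hand.

Open, going by these compounds, is how a methoxy group or an amine at this place would compare with chloro and cyano.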